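Swapping the Aryl Group on the Amine Nitrogen

The compounds below may be only part of what the source reports. "The series", "measured", "known", "first", "only" and "open" are said of these compounds alone.

Three compounds share one core and differ only in the aryl group carried on a nitrogen on an aromatic ring. In a functional assay on SK-HEP1 cells (Homo sapiens) for cytotoxicity, read by sulforhodamine B assay, with a stated time of 72 h (on this read-out higher numbers stand for weaker inhibition and lower numbers for stronger inhibition), compound 1 `CCS(=O)(=O)Nc1cc(-c2ccc3ncnc(Nc4cccc(F)c4)c3c2)cnc1OC` gives 1850 nM, compound 2 `CCS(=O)(=O)Nc1cc(-c2ccc3ncnc(Nc4ccc(OC(F)(F)F)cc4)c3c2)cnc1OC` gives 6140 nM, and compound 3 `CCS(=O)(=O)Nc1cc(-c2ccc3ncnc(Nc4ccc(OC)c(OC)c4)c3c2)cnc1OC` gives 2840 nM. Compound 3 thus holds the second-highest of the three numbers: the step of a 1.5-fold higher number from compound 1 to compound 3 (0.19 log units; within the scatter) stays within the scatter, while a 2.2-fold lower number from compound 2 to compound 3 (0.33 log units; beyond the scatter) lies beyond it. Compound 4 `CCS(=O)(=O)Nc1cc(-c2ccc3ncnc(Nc4ccc(Cl)c(C(=O)OC)c4)c3c2)cnc1OC` carries the change (4-chloro-3-(methoxycarbonyl)phenyl in place of 3,4-dimethoxyphenyl on a nitrogen on an aromatic ring). Every measured step alters this same group; a 3.3-fold higher number from compound 1 to compound 2 (0.52 log units; beyond the scatter) is the largest of them, and the whole spread is modest. A modest step of uncertain direction is therefore expected in this assay, a 1.0-fold lower number from compound 3 to compound 4 (0.01 log units; within the scatter). Compound 4 is estimated at 2800 nM, with a range from 1000 nM to 8000 nM.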

Compound 4, half-maximal inhibitory concentration: 7060 nM
Compound 4: middle estimate off by 2.5-fold (0.40 log units), on the low side, within the range that was stated.
By their numbers in this assay, from the lowest: compounds 1 and 3 (each within the scatter of the next); then compounds 2 and 4 (each within the scatter of the next).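

The step of a 2.5-fold higher number from compound 3 to compound 4 (0.40 log units; beyond the scatter) shows that this aryl group can move the number beyond the scatter even when the group entering has the same count of hydrogen-bond acceptors as the one leaving. The step of a 1.1-fold higher number from compound 2 to compound 4 (0.06 log units; within the scatter) puts two differently substituted aryl groups level, while a 3.8-fold higher number from compound 1 to compound 4 (0.58 log units; beyond the scatter) is now the largest step seen in this assay at this position. Nothing available explains these differences. Compound 4 carries chlorine and methoxycarbonyl together, which leaves their separate contributions open. From the compounds shown here alone, how an aryl group bearing an amine or a carboxylic acid would behave here also remains open.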